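The source may report more compounds than this note shows. Statements on the series, on what has been measured and on what is new or still open speak of the compounds shown alone.

Of the compounds shown here, three have been measured in a functional assay on the whole organism (strain albino) for inhibition, with Rattus norvegicus as the target, read by paw edema, with a stated time of 4 h, at a dose of 0.28 mmol/kg by the oral route; on this read-out lower numbers stand for less inhibition and higher numbers for more inhibition at the one dose given (going by the name of the read-out). Compound 3 `COc1ccc(-c2nnc(SC/C(=N/O)c3ccccc3)n2-c2ccccc2)cc1OC` gives 81% in this assay. Compound 2 `C=CCn1c(SC/C(=N/O)c2ccccc2)nnc1-c1ccc(OC)cc1` gives 76% in this assay; this number and that of compound 3 lie within the scatter of one another. Compound 2 and compound 3 are built on different cores, and the difference between the two cores is not broken down here. Compound 1 `COc1ccc(-c2nnc(SCC(=O)c3ccccc3)n2-c2ccccc2)cc1OC` gives 65% in this assay. Compound 1 arises from compound 3 through a single change, (a group of 8 heavy atoms (7 carbon, 1 oxygen; one six-membered aromatic ring of carbon only) in place of a group of 9 heavy atoms (7 carbon, 1 nitrogen, 1 oxygen; one six-membered aromatic ring of carbon only), on a saturated chain carbon bound to a sulfur). Measured, that change made a step of a number 16 percentage points lower from compound 3 to compound 1 (beyond the scatter).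

Compound 4 `C=CCn1c(SCC(=O)c2ccccc2)nnc1-c1ccc(OC)cc1` is not yet measured. It stands to compound 2 exactly as compound 1 stands to compound 3, through (a group of 8 heavy atoms (7 carbon, 1 oxygen; one six-membered aromatic ring of carbon only) in place of a group of 9 heavy atoms (7 carbon, 1 nitrogen, 1 oxygen; one six-membered aromatic ring of carbon only), on a saturated chain carbon bound to a sulfur). The place of the change is described in the same words for both pairs, so it is the same change, and it appears in two pairs among the compounds shown. Among the compounds with values here, only one of those pairs has been measured, so any expectation for compound 4 rests on that single example together with the number of compound 2, 76%. In this assay the expected step is a number 16 percentage points lower from compound 2 to compound 4 (beyond the scatter), taken to be about the size of the measured one, with a wider range allowed since the two cores differ in ways not broken down here. Compound 4 is therefore estimated at 60% in this assay, expected to fall between 48% and 72%.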

Compound 4, a percentage reported as inhibition, in the whole organism at one dose (the size of the read-out at that dose, not a potency): 67%
Compound 4: middle estimate off by 7 percentage points, on the low side; the measured number falls inside the stated range.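

On the core of compound 2, putting benzoyl in place of the group of 9 heavy atoms, on a saturated chain carbon bound to a sulfur, gives in this assay a step of a number 9 percentage points lower from compound 2 to compound 4 (within the scatter). Both steps run in the same direction, and their sizes cannot be told apart, so the change appears to carry from one core to the other at about the same size: the same change on two cores in this assay, a number 16 percentage points lower (beyond the scatter) from compound 3 to compound 1 and a number 9 percentage points lower (within the scatter) from compound 2 to compound 4, 7 percentage points apart, within the scatter of two such steps

Within the data shown here, this agreement rests on only two pairs, and the step on the core of compound 2 cannot be told from scatter on its own, so it does not show that the change lowers the number on every core, and it does not fix the true size of the step.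

The compounds shown leave open how other groups would behave at this place on the chain, such as a carboxylic acid, an amine or a longer carbon chain. They also leave open whether the two steps would stay alike on a third core, or at doses and times other than the single ones used here.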